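Amino for chloro on a purine-based growth inhibitor series

The source may report more compounds than this note shows. Statements on the series, on what has been measured and on what is new or still open speak of the compounds shown alone.

Compound 1 `Nc1nc(Cl)c2ncn(Cc3ccc(CCl)cc3)c2n1`: 22900 nM
Compound 2 `ClCc1cccc(Cn2cnc3c(Cl)nc(Cl)nc32)c1`: 2040 nM
Compound 3 `ClCc1ccc(Cn2cnc3c(Cl)nc(Cl)nc32)cc1`: 3160 nM

Three compounds were measured in a functional assay on SNB-75 cells (Homo sapiens) for cytotoxicity, read by sulforhodamine B assay, with a stated time of 48 h; a higher number here means a weaker inhibitor of growth, a lower number a stronger inhibitor of growth. Compound 2 and compound 3 have the same atoms joined differently; the difference between the two cores is not broken down here, and their values lie within the scatter of each other. Compound 3 and compound 1 differ by one change, (amino in place of chloro on an aromatic carbon), which gave a 7.2-fold higher number from compound 3 to compound 1 (0.86 log units; beyond the scatter).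

The unmeasured compound 4 `Nc1nc(Cl)c2ncn(Cc3cccc(CCl)c3)c2n1` stands to compound 2 as compound 1 stands to compound 3: amino in place of chloro on an aromatic carbon, the same change. Because the earlier step was a 7.2-fold higher number from compound 3 to compound 1 (0.86 log units; beyond the scatter), a step of similar size is expected here, a 7.2-fold higher number from compound 2 to compound 4 (0.86 log units; beyond the scatter). Compound 4 is therefore estimated at 14700 nM in this assay, likely between 6000 nM and 36000 nM.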

Compound 4, concentration for 50% growth inhibition: 5750 nM
For compound 4 the middle estimate is 2.6-fold (0.41 log units) above the measured one, and the stated range ends above it.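

In this assay, amino in place of chloro on an aromatic carbon gave a 2.8-fold higher number from compound 2 to compound 4 (0.45 log units; beyond the scatter). The change thus went the same way on both cores, and the sizes of the two steps cannot be told apart: the same change on two cores in this assay, a 7.2-fold higher number (0.86 log units; beyond the scatter) from compound 3 to compound 1 and a 2.8-fold higher number (0.45 log units; beyond the scatter) from compound 2 to compound 4, 2.6-fold (0.41 log units) apart, within the scatter of two such steps. This is one pair of steps on two cores in a single assay, so it does not show that the change would carry to any other core, nor does it say why the number rises.

The compounds shown leave open whether a methylamino or methoxy group on that same aromatic carbon would give a similar step. They also leave open what a hydroxymethyl group in place of the chloromethyl group would do.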